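Taking one methoxy off compound 3

The compounds below may be only part of what the source reports. "The series", "measured", "known", "first", "only" and "open" are said of these compounds alone.

Of the compounds shown here, three built on a shared core have been tested in a functional assay on B16 cells (Mus musculus) for cytotoxicity, read by MTT assay, with a stated time of 72 h; on this read-out lower numbers stand for stronger inhibition and higher numbers for weaker inhibition. Compound 1 `COc1cc(C2=NN(C(C)=O)C(c3ccc([N+](=O)[O-])cc3)C2)cc(OC)c1OC` gives 51000 nM. Compound 2 `COc1ccccc1C1CC(c2cc(OC)c(OC)c(OC)c2)=NN1C(C)=O` reads > 100000 nM, which is a limit of the assay and not a number. Compound 3 `COc1ccc(OC)c(C2CC(c3cc(OC)c(OC)c(OC)c3)=NN2C(C)=O)c1` reads > 100000 nM, also a limit and not a number. Compound 3 therefore stands at the limit of > 100000 nM in this assay, at which 2 of the 3 values shown sit.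

Compound 4 `COc1cccc(C2CC(c3cc(OC)c(OC)c(OC)c3)=NN2C(C)=O)c1` differs from compound 3 in one place: hydrogen in place of methoxy on an aromatic carbon, ortho to a large group and para to a methoxy group (hydrogen in place of methoxy on an aromatic carbon). This turns 2,5-dimethoxyphenyl into 3-methoxyphenyl.

The nearest measured change also concerns a methoxy on this ring, and it gives a step that the two limits leave unreadable from compound 2 to compound 3. Two further measured changes replace the 4-nitrophenyl, giving an at least 1.9-fold higher number from compound 1 to compound 2 (0.29 log units; that floor lies within the scatter) and an at least 1.9-fold higher number from compound 1 to compound 3 (0.29 log units; that floor lies within the scatter). None of these offers a firm size to carry over, so no step beyond the scatter is expected in this assay, and no direction can be favoured. The expected change is an at least 1.1-fold lower number from compound 3 to compound 4 (0.04 log units; that floor lies within the scatter). The estimate for compound 4 is 90000 nM. The expected range for compound 4 runs from 40000 nM to 200000 nM.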

Compound 4, half-maximal inhibitory concentration: > 100000 nM
Compound 4: no number, only a limit; the forecaster's own chance of this, stated with the estimate: 55%; middle value at least 1.1-fold (0.04 log units) away from the limit.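

Taking the methoxy off compound 3 leaves a 3-methoxyphenyl group, and this change brings no readable activity into this assay. Compound 4 joins compound 2 and compound 3 at the same ceiling, so three different methoxy-bearing rings now share one result: the limit of > 100000 nM in this assay, at which 3 of the 4 values shown sit. With limits at both ends, the steps linking compound 4 to compound 2 and to compound 3 cannot be read, while the comparison with the 4-nitrophenyl compound gives an at least 1.9-fold higher number from compound 1 to compound 4 (0.29 log units; that floor lies within the scatter), so even this step does not clearly separate the two compounds.

The compounds shown cannot say whether the methoxy on this ring matters at all, since a compound sitting at a limit could lie just past it or far beyond it, and removing a methoxy may therefore have changed something that this read-out does not capture. For the compounds shown here, also open is whether a quite different group on this ring, such as an amine or a carboxylic acid, would give a real number in this assay, and whether any such number would clearly differ from that of compound 1, the only compound here with a measured value.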